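A few compounds are considered here, and "the series" means these few. Any claim that something is new, unique, unknown or untested is made for them only; others in the source may bear on it.

Measured compounds:
compound 1, `Cc1cc(-c2cccnc2)ccc1C(N)=O`: in an assay on cells for inhibition of MAP kinase-interacting serine/threonine-protein kinase 1 (Homo sapiens), read by mobility shift assay, with stated times of 10 min and 60 min, in the presence of a further agent that is not named here (on this read-out higher numbers stand for weaker inhibition and lower numbers for stronger inhibition), compound 1 gives 22000 nM
compound 2, `NC(=O)c1ccc(-c2cncc(Cl)c2)cc1`: in this assay compound 2 gives 14200 nM
compound 3, `CC(C)Oc1cc(-c2cncc(-c3cnn(C)c3)c2)ccc1C(N)=O`: in this assay compound 3 gives 400 nM

Of the three numbers, compound 1 gives the highest. Compound 2 lies nearest to it, and the gap between the two is within the scatter, so nothing separates them. Compound 3 stands furthest from compound 1, with a gap that is well beyond the scatter; compound 3 also differs from compound 1 in more than one place, so no single change can be read from that gap.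

Compound 4, `NCCOc1cc(-c2cccnc2)ccc1C(N)=O`, arises from compound 1 by a single change: 2-aminoethoxy in place of methyl on an aromatic carbon, ortho to a carbamoyl group. Among the measured compounds shown here, no measured pair shows this change on its own. The expectation is a modest step toward a lower number in this assay, possibly not beyond the scatter, because compound 3, which carries an alkoxy group at the same place, gives 400 nM. For compound 4 the estimated value is 12000 nM, within 3000 nM to 40000 nM. The expected step of a 1.8-fold lower number from compound 1 to compound 4 (0.26 log units; within the scatter) is small.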

Compound 4, half-maximal inhibitory concentration: 820 nM
Beside the measured number, compound 4's estimate is 15-fold (1.17 log units) above it, outside the stated range (below it).
By their numbers in this assay, from the lowest: compound 3; then compound 4; then compounds 2 and 1 (each within the scatter of the next).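

In this assay, putting 2-aminoethoxy in place of methyl on the aromatic carbon ortho to a carbamoyl group brings a 27-fold lower number from compound 1 to compound 4 (1.43 log units; beyond the scatter), a large step beyond the scatter. The earlier compounds shown here included no pair differing in one place, so none of them could show what this position does on its own. This pair shows that a change at this position alone, with the rest of the core of compound 1 untouched, is enough to move the number far beyond the scatter. Nothing at hand bears on why the number falls so far. The compounds shown leave open whether the step follows the ether oxygen, the chain or the terminal amine. A plain ethoxy group, a methoxyethoxy group or a longer chain ending in an amine at this position would separate these parts.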